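Swapping Chloro for Methoxy on a Fused Core

A few compounds are considered here, and "the series" means these few. Any claim that something is new, unique, unknown or untested is made for them only; others in the source may bear on it.

For the measured compounds named here, compound 2 `Cc1c(Cl)nnc2sc(C(=O)NC3CN(c4ncc(C(F)(F)F)cn4)C3)c(N)c12` gives 51.9 mL/min/kg in an ADME assay (Rattus norvegicus) for pharmacokinetics (a lower number here means slower removal, a higher number faster removal of the compound), the higher of the two numbers so far; compound 1 `Cc1c(CF)nnc2sc(C(=O)NC3CN(c4ncc(C(F)(F)F)cn4)C3)c(N)c12` gives 23.7 mL/min/kg. Going by the values given here, the only measured step, a 2.2-fold higher number from compound 1 to compound 2 (0.34 log units; beyond the scatter), concerns a different change. Compound 3 `COc1nnc2sc(C(=O)NC3CN(c4ncc(C(F)(F)F)cn4)C3)c(N)c2c1C` carries methoxy in place of chloro on an aromatic carbon. Among the compounds with values here, no measured step covers this change, so the expectation rests only on the size of the one measured step, and an expected step of a 1.5-fold lower number from compound 2 to compound 3 (0.17 log units; within the scatter), small and possibly within the scatter, seems reasonable. Compound 3 is therefore estimated at 35 mL/min/kg, within a range from 15 mL/min/kg to 80 mL/min/kg.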

Compound 3, clearance: 30.5 mL/min/kg
Compound 3: middle estimate off by 1.1-fold (0.06 log units), on the high side; the range from low to high includes it.
By their numbers in this assay, from the lowest: compounds 1, 3 and 2 (each within the scatter of the next, the first and the last beyond it).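

Methoxy in place of chloro on this aromatic carbon, next to the ring nitrogen, gives a 1.7-fold lower number from compound 2 to compound 3 (0.23 log units; within the scatter) in this assay and methoxy in place of fluoromethyl gives a 1.3-fold higher number from compound 1 to compound 3 (0.11 log units; within the scatter) on the same read-out. Compound 3 therefore cannot be separated from either compound 1 or compound 2, even though those two differ from each other beyond the scatter. Nothing available bears on the reason for this result.

Going by these compounds, whether an amine, a nitrile or a longer chain such as ethoxy at this position would stand clearly apart from these three remains open.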